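The source may hold more compounds than are shown below. What is called first, only, known or untested is meant among the compounds shown, and "the series" means these compounds.

Measured compounds:
compound 1 `CCCCCc1ccc(-c2cn(C[C@H](O)[C@H]3OC(=O)C(OCc4ccccc4)=C3OCc3ccccc3)nn2)cc1` gives 8390 nM in a functional assay on HeLa cells (Homo sapiens) for antiproliferative activity, read by MTT assay, with a stated time of 72 h; on this read-out higher numbers stand for weaker inhibition and lower numbers for stronger inhibition
compound 2 `CCCCCCCCCCc1cn(C[C@H](O)[C@H]2OC(=O)C(OCc3ccccc3)=C2OCc2ccccc2)nn1` gives 22900 nM in this assay
compound 3 `CC(C)(C)c1cn(C[C@H](O)[C@H]2OC(=O)C(OCc3ccccc3)=C2OCc2ccccc2)nn1` gives 18300 nM in this assay

On these numbers compound 3 stands second highest of the three. Its nearest neighbour is compound 2, with a 1.3-fold lower number from compound 2 to compound 3 (0.10 log units; within the scatter) lying within the scatter, while compound 1 sits furthest off, with a 2.2-fold higher number from compound 1 to compound 3 (0.34 log units; beyond the scatter) lying beyond it. Compound 4 `Cc1ccc(S(=O)(=O)NCc2cn(C[C@H](O)[C@H]3OC(=O)C(OCc4ccccc4)=C3OCc3ccccc3)nn2)cc1` differs from compound 3 by (((4-methylphenyl)sulfonyl)amino)methyl in place of tert-butyl on an aromatic carbon. The steps bearing on this sit at the same aromatic carbon: a 2.2-fold higher number from compound 1 to compound 3 (0.34 log units; beyond the scatter) and a 1.3-fold lower number from compound 2 to compound 3 (0.10 log units; within the scatter), with a 2.7-fold higher number from compound 1 to compound 2 (0.44 log units; beyond the scatter) completing the picture. For the measured compounds named here, the only step beyond the scatter there goes with the 4-pentylphenyl group of compound 1, and the entering group also carries a six-membered aromatic ring, though its remaining parts have no counterpart among the measured compounds. A modest step to a lower number, a 1.5-fold lower number from compound 3 to compound 4 (0.18 log units; within the scatter), is therefore expected. Compound 4 is estimated at 12000 nM, within 4000 nM to 36000 nM.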

Compound 4, half-maximal inhibitory concentration: 14400 nM
The estimate for compound 4 lay 1.2-fold (0.08 log units) below the measured number, and the stated range covers the measured number.
By their numbers in this assay, from the lowest: compounds 1, 4, 3 and 2 (each within the scatter of the next, the first and the last beyond it).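

In this assay, the (((4-methylphenyl)sulfonyl)amino)methyl group on this aromatic carbon gives a 1.3-fold lower number from compound 3 to compound 4 (0.10 log units; within the scatter) and a 1.6-fold lower number from compound 2 to compound 4 (0.20 log units; within the scatter) and also a 1.7-fold higher number from compound 1 to compound 4 (0.23 log units; within the scatter) at the same place. The earlier compounds shown here carried only carbon groups here, whereas this group adds nitrogen, oxygen and sulfur, with a hydrogen-bond donor and acceptors, and all three new steps stay within the scatter. Nothing measured here offers a reason for this. Still open, going by these compounds, is whether a simple amine or a carboxylic acid on this carbon would give a step beyond the scatter. On these data alone, it is also open whether the methyl link or the 4-methyl group of the entering group matters.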